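Shortening the alkoxy chain on a dione core

The source may hold more compounds than are shown below. What is called first, only, known or untested is meant among the compounds shown, and "the series" means these compounds.

Compound 3 `CCCC1=C(OCC)C(CCC)(CCC)C(=O)/C(=C(O)\C=C\c2ccccc2)C1=O` is tested in a functional assay on PC-3 cells (Homo sapiens) for antiproliferative activity, read by sulforhodamine B assay, with a stated time of 3 days (on this read-out higher numbers stand for an effect only at larger amounts of compound and lower numbers for an effect already at smaller amounts), where compound 3 gives 12.5 uM. Of the three numbers recorded, this is the highest. Compound 1 `CCCC1=C(OCC(C)C)C(CCC)(CCC)C(=O)/C(=C(O)\C=C\c2ccccc2)C1=O` gives 12.2 uM in this assay, and the step of a 1.0-fold higher number from compound 1 to compound 3 (0.01 log units; within the scatter) lies within the scatter. Compound 2 `CCCC1=C(OC)C(CCC)(CCC)C(=O)/C(=C(O)\C=C\c2ccc(I)cc2)C1=O` gives 2.8 uM; it differs from compound 3 in two places, so its lower number cannot be assigned to either change on its own.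

Compound 4 `CCCC1=C(OC)C(CCC)(CCC)C(=O)/C(=C(O)\C=C\c2ccccc2)C1=O` has not yet been measured in this assay. It differs from compound 3 in one place: hydrogen in place of methyl on a saturated chain carbon bound to an oxygen on an unsaturated carbon. Among the compounds with values here, only one measured step concerns the same saturated chain carbon bound to an oxygen on an unsaturated carbon, namely the step from compound 1 to compound 3, and that step was within the scatter. On that basis the step of a 1.0-fold lower number from compound 3 to compound 4 (0.02 log units; within the scatter) is expected to stay within the scatter too, with no clear direction. Compound 4 is therefore estimated at 12 uM in this assay, in a range from 6 uM to 25 uM.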

Compound 4, concentration for half-maximal effect: 8.2 uM
For compound 4 the middle estimate is 1.5-fold (0.17 log units) above the measured one; low and high end bracket the measured number.
By their numbers in this assay, from the lowest: compound 2; then compounds 4, 1 and 3 (each within the scatter of the next).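

In this assay hydrogen in place of methyl, which turns ethoxy into methoxy, gives a 1.5-fold lower number from compound 3 to compound 4 (0.18 log units; within the scatter) and hydrogen in place of isopropyl on the same saturated chain carbon gives a 1.5-fold lower number from compound 1 to compound 4 (0.17 log units; within the scatter) so the three compounds without iodo all lie within the scatter of one another across this change. Within the data shown here, compound 4 also isolates the iodo group for the first time, since hydrogen in place of iodo on an aromatic carbon gives a 2.9-fold higher number from compound 2 to compound 4 (0.47 log units; beyond the scatter) and this step, beyond the scatter, is a modest one that no earlier pair could separate from the alkoxy change. No measurement at hand accounts for either result.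

From the compounds shown here alone, whether a much longer chain on this oxygen, or an amine at its end, would stay within the scatter remains open. So does whether bromo or chloro on the aromatic carbon would give a step like that of iodo, and whether the iodo step holds with ethoxy in place of methoxy.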